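A few compounds are considered here, and "the series" means these few. Any claim that something is new, unique, unknown or untested is made for them only; others in the source may bear on it.

Measured compounds:
- compound 1, `CCCCOc1ccc(S(=O)(=O)N2CCCC[C@H]2CC(=O)N[C@@H]2CCCc3cc(CNC(C)(C)C)ccc32)cc1`, 1200 nM
- compound 2, `COc1ccc(S(=O)(=O)N2CCCC[C@H]2CC(=O)N[C@@H]2CCCc3cc(CNC(C)(C)C)ccc32)cc1`, 780 nM
- compound 3, `Cc1ccc(S(=O)(=O)N2CCCC[C@H]2CC(=O)N[C@@H]2CCCc3cc(CNC(C)(C)C)ccc32)cc1C(F)(F)F`, 11 nM

In an assay on isolated protein for inhibition of B1 bradykinin receptor (Homo sapiens) (a lower number here means a stronger inhibitor, a higher number a weaker inhibitor), compound 2 stands second highest of the three numbers; its nearest neighbour is compound 1, and the step of a 1.5-fold lower number from compound 1 to compound 2 (0.19 log units; within the scatter) lies within the scatter, while a 71-fold lower number from compound 2 to compound 3 (1.85 log units; beyond the scatter) is large. Compound 4, `CC(C)(C)NCc1ccc2c(c1)CCC[C@H]2NC(=O)C[C@@H]1CCCCN1S(=O)(=O)c1cccc2cnccc12`, has not been measured; it differs from compound 2 in one place: isoquinolin-5-yl in place of 4-methoxyphenyl on a sulfonyl sulfur. Within the data shown here, the steps that bear on a change of the group on the sulfonyl sulfur are a 110-fold lower number from compound 1 to compound 3 (2.04 log units; beyond the scatter) and a 71-fold lower number from compound 2 to compound 3 (1.85 log units; beyond the scatter), both large drops, but both lead to the 4-methyl-3-(trifluoromethyl)phenyl group, not to isoquinolin-5-yl; no measured compound carries a bicyclic group there, so the expectation rests on a loose analogy only. A moderate step downward is therefore expected, estimated as a 3.1-fold lower number from compound 2 to compound 4 (0.49 log units; beyond the scatter), smaller than the steps to compound 3. For compound 4 the estimate in this assay is 250 nM, with a range from 50 nM to 1500 nM.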

Compound 4, half-maximal inhibitory concentration: 610 nM
For compound 4 the middle estimate is 2.4-fold (0.39 log units) below the measured one, within the range that was stated.
By their numbers in this assay, from the lowest: compound 3; then compounds 4, 2 and 1 (each within the scatter of the next).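

In this assay, among these compounds, a group of two fused aromatic rings stands on the sulfonyl sulfur for the first time, and isoquinolin-5-yl stays level with both alkoxyphenyl groups, with a 1.3-fold lower number from compound 2 to compound 4 (0.11 log units; within the scatter) and a 2.0-fold lower number from compound 1 to compound 4 (0.29 log units; within the scatter). The distance to the 4-methyl-3-(trifluoromethyl)phenyl group is large, at a 55-fold higher number from compound 3 to compound 4 (1.74 log units; beyond the scatter), so a second aromatic ring on the sulfur does not by itself match that group, and compound 3 remains alone at the low end of the four. Nothing available offers an explanation for this pattern.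

Going by these compounds, it remains open whether the methyl, the trifluoromethyl or the two together account for the low number of compound 3, which 4-methylphenyl and 3-(trifluoromethyl)phenyl would separate. Naphthalen-1-yl on the sulfonyl sulfur would show whether the ring nitrogen of isoquinolin-5-yl matters.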